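A few compounds are considered here, and "the series" means these few. Any claim that something is new, unique, unknown or untested is made for them only; others in the source may bear on it.

Of the compounds shown here, three that share one core have been tested in an assay on isolated protein for agonist activity at Bile acid receptor (Homo sapiens), read by AlphaScreen, with a stated time of 30 min; a higher number here means that more compound is needed for the effect, a lower number that less compound is needed. Compound 1 `Cc1ccccc1-n1nc(C)c2c1NC(=O)[C@H](C)S[C@@H]2c1ccc(-c2ccoc2)cc1` gives 3500 nM, compound 2 `Cc1ccccc1-n1nc(C)c2c1NC(=O)[C@H](C)S[C@@H]2c1ccc(-c2ccsc2)cc1` gives 1400 nM, and compound 3 `Cc1ccccc1-n1nc(C)c2c1NC(=O)[C@H](C)S[C@@H]2c1ccc(-c2ccco2)cc1` gives 3600 nM, the highest of the three numbers; its gap to compound 1 lies within the scatter, whereas a 2.6-fold higher number from compound 2 to compound 3 (0.41 log units; beyond the scatter) lies beyond it. Compound 4 `COc1cccc(Oc2ccc([C@H]3S[C@@H](C)C(=O)Nc4c3c(C)nn4-c3ccccc3C)cc2)c1` differs from compound 3 in one place: 3-methoxyphenoxy in place of furan-2-yl on an aromatic carbon. Among the compounds with values here, every measured step so far swaps one small five-membered ring for another, as in a 2.5-fold lower number from compound 1 to compound 2 (0.40 log units; beyond the scatter) and a 1.0-fold higher number from compound 1 to compound 3 (0.01 log units; within the scatter), and none is larger than modest; no measured step replaces such a ring with a 3-methoxyphenoxy group, so the guidance is thin. A step of a 1.4-fold lower number from compound 3 to compound 4 (0.16 log units; within the scatter) is expected, giving compound 4 an estimated 2500 nM, most likely between 700 nM and 9000 nM.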

Compound 4, half-maximal effective concentration: 1700 nM
For compound 4 the middle estimate is 1.5-fold (0.17 log units) above the measured one; measured number inside the range.
By their numbers in this assay, from the lowest: compounds 2 and 4 (each within the scatter of the next); then compounds 1 and 3 (each within the scatter of the next).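

At this position, para to a large group, the site is not limited to small five-membered rings: the larger 3-methoxyphenoxy group gives a 2.1-fold lower number from compound 3 to compound 4 (0.33 log units; beyond the scatter) and a 2.1-fold lower number from compound 1 to compound 4 (0.31 log units; beyond the scatter) against the two furans. Against thiophen-3-yl the step is a 1.2-fold higher number from compound 2 to compound 4 (0.08 log units; within the scatter) and so does not separate the two groups. Nothing available explains these differences. The compounds shown leave open whether the methoxy group or the linking oxygen matters, as plain phenoxy would test. Going by these compounds, how an amine or a carboxylic acid would behave here also remains open.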